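The compounds below may be only part of what the source reports. "The series", "measured", "known", "first", "only" and "open" are said of these compounds alone.

Measured compounds:

Compound 1, `COC(=O)c1ccc2ccc(C(=O)c3ccccc3)c-2cc1`, in an assay on cells for displacement of a labelled ligand from Orexin/Hypocretin receptor type 1 (Homo sapiens), read by scintillation counting, with stated times of 10 min and 90 min, tested at 10 uM (on this read-out lower numbers stand for less inhibition and higher numbers for more inhibition at the one concentration tested (going by the name of the read-out)), gives 7.2%.
Compound 2, `COC(=O)c1ccc2ccc(C(=O)c3ccc(C(F)(F)F)cc3)c-2cc1`, in this assay gives -60.5%.
Compound 3, `COC(=O)Cc1ccc2ccc(C(=O)c3ccccc3)c-2cc1`, in this assay gives -37.7%.

All three numbers lie at or below the zero line, so none of these compounds shows appreciable displacement of the labelled ligand. Compound 1 gives the highest of the three, and the other two sit well below it.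

Two single changes connect them. From compound 1 to compound 2 the change is trifluoromethyl in place of hydrogen on an aromatic carbon, and in this assay this gave a number 67.7 percentage points lower from compound 1 to compound 2 (beyond the scatter). From compound 1 to compound 3 the cores differ by (methoxycarbonyl)methyl in place of methoxycarbonyl on an aromatic carbon, which gave a number 44.9 percentage points lower from compound 1 to compound 3 (beyond the scatter). Compound 3 stands between the other two, and its gap to compound 2 is beyond the scatter.

Compound 4, `COC(=O)Cc1ccc2ccc(C(=O)c3ccc(C(F)(F)F)cc3)c-2cc1`, has not yet been measured. It differs from compound 3 by trifluoromethyl in place of hydrogen on an aromatic carbon, the same change that separates compound 1 from compound 2, since the two place descriptions match word for word. The step is seen only once, and it began from a compound that was itself close to zero, so its size cannot be taken as firmly established. A step of similar direction is nevertheless expected, and because a number 67.7 percentage points lower from compound 1 to compound 2 (beyond the scatter) was large, compound 4 is estimated to fall below compound 3 by a number 32.3 percentage points lower from compound 3 to compound 4 (beyond the scatter). Compound 4 is therefore expected to give about -70% in this assay, most likely between -110% and -30%.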

Compound 4, a percentage reported as inhibition, at one concentration (the size of the read-out at that concentration, not a potency): -30.4%
For compound 4 the middle estimate is 39.6 percentage points below the measured one; low and high end bracket the measured number.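

In this assay, within the data shown here, trifluoromethyl in place of hydrogen on an aromatic carbon gave a number 7.3 percentage points higher from compound 3 to compound 4 (within the scatter), so the large drop seen on the core of compound 1 did not carry over to the core of compound 3: the same change on two cores in this assay, a number 67.7 percentage points lower (beyond the scatter) from compound 1 to compound 2 and a number 7.3 percentage points higher (within the scatter) from compound 3 to compound 4, 75 percentage points apart, beyond the scatter of two such steps The other change, (methoxycarbonyl)methyl in place of methoxycarbonyl on an aromatic carbon, also failed to carry over, giving a number 30.1 percentage points higher from compound 2 to compound 4 (beyond the scatter), opposite in direction to its earlier step: the same change on two cores in this assay, a number 44.9 percentage points lower (beyond the scatter) from compound 1 to compound 3 and a number 30.1 percentage points higher (beyond the scatter) from compound 2 to compound 4, 75 percentage points apart, beyond the scatter of two such steps Within these four compounds, then, the size and direction of each step depend on what else the molecule carries, so neither step can be transferred as a fixed increment, but each change is seen on only two cores and the data give no reason for the mismatch, nor do they show any change that produces appreciable displacement of the labelled ligand.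

The compounds shown leave open how a carboxylic acid or an amide would read in this assay in place of the methoxycarbonyl group, and whether a longer chain would extend the trend or break it. They also leave open whether a nitrile or a chlorine atom in place of trifluoromethyl would follow either of the two cores.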